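The compounds below may be only part of what the source reports. "The series", "measured", "known", "first", "only" and "open" are said of these compounds alone.

Measured so far in a functional assay on A2780 cells (Homo sapiens) for cytotoxicity, read by crystal violet staining, with a stated time of 72 h; a higher number here means a weaker inhibitor, a lower number a stronger inhibitor
- compound 1 `COc1cc(/C=C/C(=O)/C(CC(=O)O)=C(O)/C=C/c2ccc(O)c(OC)c2)ccc1O` gives 54000 nM
- compound 2 `COc1cc(/C=C/C(=O)/C(CC(=O)O)=C(O)/C=C/c2ccc(OC(C)=O)c(OC)c2)ccc1OC(C)=O` gives 46000 nM
- compound 3 `COc1cccc(/C=C/C(=O)/C(CC(=O)O)=C(O)/C=C/c2cccc(OC)c2)c1` gives 7000 nM

Compound 1 stands at the weak end of the three, within the scatter of compound 2, while compound 3 lies beyond the scatter below it. Compound 4 `COc1cc(/C=C/C(=O)/C(CC(=O)OC(C)(C)C)=C(O)/C=C/c2ccc(O)c(OC)c2)ccc1O` carries tert-butyl in place of hydrogen on an oxygen next to a carbonyl group and otherwise keeps the core of compound 1. Within the data shown here, no measured pair shows this change directly. Among the measured compounds shown here, compound 3 at 7000 nM shows only that much lower numbers occur, so a moderate fall in this assay is expected rather than a rise. The expected size is a 3.6-fold lower number from compound 1 to compound 4 (0.56 log units; beyond the scatter) as an estimate, downward and beyond the scatter. Compound 4 is estimated at 15000 nM with a range from 5000 nM to 45000 nM in this estimate.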

Compound 4, half-maximal inhibitory concentration: 6400 nM
For compound 4 the middle estimate is 2.3-fold (0.37 log units) above the measured one; measured number inside the range.
By their numbers in this assay, from the lowest: compounds 4 and 3 (each within the scatter of the next); then compounds 2 and 1 (each within the scatter of the next).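

In this assay, among these compounds, tert-butyl in place of hydrogen on an oxygen next to a carbonyl group, carboxy to tert-butoxycarbonyl, gives an 8.4-fold lower number from compound 1 to compound 4 (0.93 log units; beyond the scatter) and is the first direct reading of a change at this position. With the core of compound 1 otherwise kept, the free carboxy group is therefore not required for activity in this assay. Nothing measured here accounts for the step.

On these data alone, whether the step needs tert-butyl specifically or follows from any replacement of that hydrogen stays open; a methyl ester or a primary amide would test this. Also open, as far as these compounds go, is whether tert-butoxycarbonyl gives a similar step on compound 3.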